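A few compounds are considered here, and "the series" means these few. Any claim that something is new, unique, unknown or untested is made for them only; others in the source may bear on it.

Working notes on the series. Among the measured compounds shown here, in a functional assay on OVCAR-3 cells (Homo sapiens) for inhibition, read by sulforhodamine B assay, with a stated time of 48 h (on this read-out higher numbers stand for lower toxicity in this test and lower numbers for higher toxicity in this test), compound 1 `Nc1cc(N)c2nc(-c3ccccc3)c(NCc3ccc(Cl)c(Cl)c3)nc2c1` gives 31600 nM, the lowest of the two numbers so far; compound 2 `Nc1cc(N)c2nc(-c3ccccc3)c(Sc3ccc(F)cc3)nc2c1` gives 69200 nM in this assay, a gap beyond the scatter. For compound 3 `CCOC(=O)[C@H](CCC(=O)O)NC(=O)c1ccc(Oc2nc3cc(N)cc(N)c3nc2-c2ccccc2)cc1` this assay reports only a limit, < 100000 nM. Compound 4 `COc1ccc(CNc2nc3cc(N)cc(N)c3nc2-c2ccccc2)cc1OC` is still to be measured; it differs from compound 1 by 3,4-dimethoxyphenyl in place of 3,4-dichlorophenyl on a saturated chain carbon bound to a nitrogen on an aromatic ring. For the measured compounds named here, no step between measured compounds covers this kind of exchange, so the expectation rests only on the spread seen between compound 1 and compound 2. Compound 4 is expected to give roughly 50000 nM in this assay, within 15000 nM to 150000 nM, meaning an expected step of a 1.6-fold higher number from compound 1 to compound 4 (0.20 log units; within the scatter) that may not exceed the scatter.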

Compound 4, concentration lethal to 50% of the cells: 8510 nM
Compound 4: middle estimate off by 5.9-fold (0.77 log units), on the high side, outside the stated range (below it).
By their numbers in this assay, from the lowest: compound 4; then compound 1; then compound 2.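

At this position, on a saturated chain carbon bound to a nitrogen on an aromatic ring, the group carried by the chain changes the read-out in this assay: 3,4-dimethoxyphenyl in place of 3,4-dichlorophenyl gives a 3.7-fold lower number from compound 1 to compound 4 (0.57 log units; beyond the scatter). Among the compounds shown here, this is the first step between compounds that differ in one place, and it shows that the exchange leads to higher toxicity in this test. No measurement shown bears on the cause of this step. Still open, from the compounds shown here alone, is whether a single methoxy group, an unsubstituted phenyl or a longer chain at this position would follow the same direction.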